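Amide nitrogen substituent in the vitamin D receptor series

This account rests on a few compounds, and the source may have more. Where it says the series, first, only, none or still open, it means among the compounds named here.

For the measured compounds named here, compound 2 `CCOC(=O)C(CC(=O)OC)NC(=O)c1ccc(C(CC)(CC)c2ccc(OCCC(O)(CC)CC)c(C)c2)n1CC` gives 21 nM in an assay on cells for agonist activity at vitamin D3 receptor (Homo sapiens), with a stated time of 96 h (on this read-out higher numbers stand for an effect only at larger amounts of compound and lower numbers for an effect already at smaller amounts), the lower of the two numbers so far; compound 1 `CCn1c(C(=O)Nc2cccc(C(F)(F)F)c2)ccc1C(CC)(CC)c1ccc(OCCC(O)(CC)CC)c(C)c1` gives 5900 nM. The step of a 280-fold lower number from compound 1 to compound 2 (2.45 log units; beyond the scatter) is the only one measured and it alters the same position as the change to compound 3 `CCn1c(C(=O)NC(C)CO)ccc1C(CC)(CC)c1ccc(OCCC(O)(CC)CC)c(C)c1`, namely (a group of 4 heavy atoms (3 carbon, 1 oxygen; no ring) in place of a group of 11 heavy atoms (7 carbon, 4 oxygen; no ring), on an amide-type nitrogen). That step shows that an aliphatic group on the amide nitrogen can give a far lower number than the aromatic one, but the group entering in compound 3 is not the one that produced it. A moderate rise is therefore expected, and compound 3 is estimated at 60 nM (range 10 nM to 400 nM), a step of a 2.9-fold higher number from compound 2 to compound 3 (0.46 log units; beyond the scatter).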

Compound 3, half-maximal effective concentration: 96 nM
Compound 3: middle estimate off by 1.6-fold (0.20 log units), on the low side; measured number inside the range.
By their numbers in this assay, from the lowest: compound 2; then compound 3; then compound 1.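

In this assay a low number on this amide-type nitrogen does not depend on the group of compound 2: 1-(hydroxymethyl)ethyl also brings a 61-fold lower number from compound 1 to compound 3 (1.79 log units; beyond the scatter) against the 3-(trifluoromethyl)phenyl group. The two aliphatic groups are still not equivalent, since a 4.6-fold higher number from compound 2 to compound 3 (0.66 log units; beyond the scatter) separates them. Nothing available explains either step. Still open, as far as these compounds go, is whether a carboxylic acid in place of the esters of compound 2 keeps the number low. Also open, from the compounds shown here alone, is whether a longer chain carrying the hydroxyl falls nearer compound 2 or compound 3.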